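Metabolic stability notes: sulfamoyl in place of isopropylsulfonyl

A few compounds are considered here, and "the series" means these few. Any claim that something is new, unique, unknown or untested is made for them only; others in the source may bear on it.

Measured compounds in an ADME assay on microsomes from liver (Mus musculus) for metabolic stability, read by LC-MS, with NADPH named in the record, with a stated time of 60 min, tested at 1 uM, in the absence of a further agent; on this read-out higher numbers stand for a more stable compound and lower numbers for a less stable compound:
compound 1, `COc1ccc(-c2c(C)oc3c(N4CC[C@@H](NC(C)=O)C4)cc(C)nc23)cc1OC`: > 95%
compound 2, `CC(=O)N[C@@H]1CCN(c2cc(C)nn3c(-c4ccc(C#N)cc4)c(C)nc23)C1`: > 95%
compound 3, `COc1ccc(-c2c(C)nc3c(N4CC[C@@H](NS(=O)(=O)C(C)C)C4)cc(C)nn23)cc1OC`: > 95%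

The value of compound 1 is a limit of this assay, not a number. The value of compound 2 is likewise a limit. The value of compound 3 is also a limit. Compound 3 therefore stands at the limit of > 95% in this assay, at which 3 of the 3 values shown sit, and nothing in the shown numbers separates it from compound 1 or compound 2. Within the data shown here, no two measured compounds differ in one place, so no measured step is available in this assay for this series.

Compound 4, `COc1ccc(-c2c(C)nc3c(N4CC[C@@H](NS(N)(=O)=O)C4)cc(C)nn23)cc1OC`, differs from compound 3 by amino in place of isopropyl on a sulfonyl sulfur. With all three measured compounds at the limit, the step for compound 4 in this assay is expected to be none beyond the scatter, i.e. a number no higher from compound 3 to compound 4 (the limit leaves the size open) is the expected change. Compound 4 is estimated at 95% in this assay, within a range from 85% to 99%, most likely again reported as a limit.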

Compound 4, percent of the compound remaining: > 95%
Compound 4 was reported as a limit; the forecaster's own chance of this, stated with the estimate: 75%; the middle value sits exactly at the limit.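

Compound 4 gives > 95% as a limit in this assay again. Compound 3 also stands at a limit, so no step between compound 3 and compound 4 can be read: the limit of > 95% in this assay, at which 4 of the 4 values shown sit.

The compounds shown leave open whether amino in place of isopropyl on a sulfonyl sulfur changes stability at all.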